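Compound 3 to compound 4: a hydroxy on the ring

This account rests on a few compounds, and the source may have more. Where it says the series, first, only, none or still open, it means among the compounds named here.

In a functional assay on HEL cells (Homo sapiens) for cytotoxicity (a higher number here means that more compound is tolerated, a lower number that less compound is tolerated), compound 1 `CCCCCCCCCCC#Cc1cc2cn([C@H]3C[C@H](O)[C@@H](CO)O3)c(=O)nc2o1` gives 36000 nM as measured, and compound 3 `CCCCCCCCC#Cc1cc2cn([C@H]3C[C@H](O)[C@@H](CO)O3)c(=O)nc2o1` gives 77000 nM as the higher of the two numbers. Compound 2 `CCCCC#Cc1cc2cn([C@H]3C[C@H](O)[C@@H](CO)O3)c(=O)nc2o1` is reported only as a limit at > 150000 nM in this series. Compound 4 `CCCCCCCCC#Cc1cc2cn([C@@H]3O[C@H](CO)[C@@H](O)[C@@H]3O)c(=O)nc2o1` differs from compound 3 at the ring and not the chain: hydroxy in place of hydrogen on a saturated ring carbon and nothing else. The measured steps all change the chain: a 2.1-fold higher number from compound 1 to compound 3 (0.33 log units; beyond the scatter) is modest and an at least 4.1-fold higher number from compound 1 to compound 2 (0.61 log units; beyond the scatter) rests on the limit, so neither tests this ring carbon. In this assay no step beyond the scatter is therefore expected, and the estimated 1.2-fold higher number from compound 3 to compound 4 (0.07 log units; within the scatter) stays small. Compound 4 is estimated at 90000 nM within an expected range of 35000 nM to 200000 nM for now.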

Compound 4, half-maximal cytotoxic concentration: > 124000 nM
Compound 4 ended at the assay's limit (the forecaster's own chance of this, stated with the estimate: 40%); at least 1.3-fold (0.13 log units) between middle value and limit.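

Among these compounds, the hydroxy on the saturated ring carbon, which turns 4-hydroxy-5-(hydroxymethyl)oxolan-2-yl into 3,4-dihydroxy-5-(hydroxymethyl)oxolan-2-yl, is the first change made away from the chain. In this assay, compound 4 is reported only as a limit: the limit of > 124000 nM in this assay, at which 1 of the 4 values shown sits. The step reads an at least 1.6-fold higher number from compound 3 to compound 4 (0.20 log units; that floor lies within the scatter), so the ring hydroxy does not lower the number here, but the size of the change stays unresolved.

As far as these compounds go, the effect of this hydroxy with the chains of compound 1 and compound 2 stays open. So does the outcome of an amine on this ring carbon.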